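Swapping the benzyl halogens on a diamino quinoxaline core

The source may report more compounds than this note shows. Statements on the series, on what has been measured and on what is new or still open speak of the compounds shown alone.

Measured compounds:
Compound 1 `CCOC(=O)[C@H](CCC(=O)O)NC(=O)c1ccc(CNc2nc3cc(N)cc(N)c3nc2-c2ccccc2)cc1`: 27500 nM
Compound 2 `Nc1cc(N)c2nc(-c3ccccc3)c(NCc3ccc(Cl)c(Cl)c3)nc2c1`: 1910 nM
Compound 3 `CCOC(=O)[C@H](CCC(=O)O)NC(=O)c1ccc(Sc2nc3cc(N)cc(N)c3nc2-c2ccccc2)cc1`: 19100 nM

In a functional assay on SK-MEL-2 cells (Homo sapiens) for inhibition, read by sulforhodamine B assay, with a stated time of 48 h (on this read-out higher numbers stand for weaker inhibition of growth and lower numbers for stronger inhibition of growth), compound 2 gives the lowest number of the three measured compounds; compound 3 sits a good deal higher and compound 1 higher still, both gaps beyond the scatter. Compound 4 `Nc1cc(N)c2nc(-c3ccccc3)c(NCc3ccc(F)cc3)nc2c1` differs from compound 2 by 4-fluorophenyl in place of 3,4-dichlorophenyl on a saturated chain carbon bound to a nitrogen on an aromatic ring. Within the data shown here, no measured pair shows this change. Two chlorines leave and one fluorine enters, a smaller substituent set on the same benzyl position. Compound 4 is expected to inhibit growth somewhat less than compound 2, with a 2.6-fold higher number from compound 2 to compound 4 (0.42 log units; beyond the scatter) estimated as a modest step toward weaker inhibition, near the edge of the scatter. Compound 4 is therefore estimated at 5000 nM, within 1500 nM to 20000 nM.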

Compound 4, concentration for 50% growth inhibition: 5250 nM
The estimate for compound 4 lay 1.1-fold (0.02 log units) below the measured number; low and high end bracket the measured number.
By their numbers in this assay, from the lowest: compound 2; then compound 4; then compounds 3 and 1 (each within the scatter of the next).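

In this assay, among these compounds, replacing 3,4-dichlorobenzyl with 4-fluorobenzyl gives a 2.7-fold higher number from compound 2 to compound 4 (0.44 log units; beyond the scatter) and so shows that the number responds to the halogens on this benzyl group, which the earlier compounds, differing in more than one place, could not show. Nothing available explains this step. Because two chlorines leave and one fluorine enters in a single step, the compounds shown leave open what each halogen contributes. An unsubstituted benzyl or a 4-chlorobenzyl group at the same place would help separate those contributions.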